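Amide to urea on the anilide arm of the series

A few compounds are considered here, and "the series" means these few. Any claim that something is new, unique, unknown or untested is made for them only; others in the source may bear on it.

Compound 3 `CN(C)CCCC(=O)Nc1ccc(CN2N=C(c3ccc(F)cc3)C3C=CC=CC3C2=O)cc1` gives 38200 nM in an ADME assay on Huh-7 cells (Homo sapiens) for cytotoxicity, read by MTT assay, with a stated time of 48 h; a higher number here means that more compound is tolerated, a lower number that less compound is tolerated. Compound 1 `Nc1ccc(CN2N=C(c3ccc(F)cc3)C3C=CC=CC3C2=O)cc1` sits at the assay limit of > 80000 nM in this assay, so for it only a limit and no number is known. Compound 2 `CN(C)CCCCN(C(=O)O)c1cccc(Cn2nc(-c3ccc(F)cc3)c3ccccc3c2=O)c1` gives 8510 nM in this assay. Among the two numbers shown, compound 3 stands highest, with compound 2 the nearest and lower, beyond the scatter. For the measured compounds named here, the one measured step, an at least 2.0-fold lower number from compound 1 to compound 3 (0.32 log units; beyond the scatter), is read against the limit of compound 1 the limit of > 80000 nM in this assay, at which 1 of the 3 values shown sits, and so gives only a floor for its size.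

Compound 4 `CN(C)CCCCNC(=O)Nc1ccc(CN2N=C(c3ccc(F)cc3)C3C=CC=CC3C2=O)cc1` is the next member. It differs from compound 3 by (4-(dimethylamino)butyl)amino in place of 3-(dimethylamino)propyl on a carbonyl carbon. Going by the values given here, no measured step changes this place; the step from compound 1 to compound 3 alters the group on the aromatic nitrogen, not the chain on the carbonyl carbon, so it bears on compound 4 only loosely. Compound 2 carries its chain on a different ring position and is not a like-for-like comparison. Among the compounds with values here, with no direct precedent, the expected step of a 1.3-fold lower number from compound 3 to compound 4 (0.10 log units; within the scatter) in this assay is small, within the scatter or at most modest in either direction. Compound 4 is therefore estimated at 30000 nM, with a range from 12000 nM to 75000 nM.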

Compound 4, half-maximal cytotoxic concentration: 46600 nM
Compound 4: middle estimate off by 1.6-fold (0.19 log units), on the low side; the measured number falls inside the stated range.
By their numbers in this assay, from the lowest: compound 2; then compounds 3 and 4 (each within the scatter of the next). At a limit, above all of these: compound 1.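

Replacing 3-(dimethylamino)propyl with (4-(dimethylamino)butyl)amino on the carbonyl carbon turns the amide of the anilide arm into a urea, and this first change at this place leaves no readable difference in this assay: a 1.2-fold higher number from compound 3 to compound 4 (0.09 log units; within the scatter). At this position, then, the amide and the urea, each with its own chain, cannot be told apart in this read-out. Measured from the free amine, the step for the urea reads an at least 1.7-fold lower number from compound 1 to compound 4 (0.23 log units; that floor lies within the scatter), so unlike the floor for the amide, this floor does not by itself establish a difference beyond the scatter, and its true size stays unknown: the limit of > 80000 nM in this assay, at which 1 of the 4 values shown sits.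

The linker and the chain change together in this step, so the contribution of each remains unresolved, and a urea carrying 3-(dimethylamino)propyl would be needed to separate them. Going by these compounds, it also remains open whether this flat reading holds for a longer chain, or for a carboxylic acid or a primary amine in place of the terminal dimethylamino group.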